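Cyclopropyl Amide in Place of a Halogenated Aryl Amide

The compounds below may be only part of what the source reports. "The series", "measured", "known", "first", "only" and "open" are said of these compounds alone.

Compound 1 `COc1ccc(NC(=O)[C@H]2CN(C)C[C@@H]2c2ccc(/C=C/C(=O)Nc3ccccc3N)cc2)cc1`, compound 2 `CC(C)c1ccc(NC(=O)[C@H]2CN(C)C[C@@H]2c2ccc(/C=C/C(=O)Nc3ccccc3N)cc2)cc1` and compound 3 `CN1C[C@H](C(=O)Nc2ccc(F)c(Br)c2)[C@@H](c2ccc(/C=C/C(=O)Nc3ccccc3N)cc2)C1` share one core and differ only in the group on the amide nitrogen. In an in vitro ADME assay on microsomes from liver (Homo sapiens) for pharmacokinetics, read by LC-MS, with a stated time of 10 min, tested at 1 uM (on this read-out higher numbers stand for fast clearance and lower numbers for slow clearance), compound 1 gives 14 mL/min/kg, compound 2 gives 10 mL/min/kg and compound 3 gives 15 mL/min/kg. Compound 3 stands at the top of these three numbers, but only by steps within the scatter: a 1.1-fold higher number from compound 1 to compound 3 (0.03 log units; within the scatter) and a 1.5-fold higher number from compound 2 to compound 3 (0.18 log units; within the scatter). Compound 4 `CN1C[C@H](C(=O)NC2CC2)[C@@H](c2ccc(/C=C/C(=O)Nc3ccccc3N)cc2)C1` alters the same nitrogen: cyclopropyl in place of 3-bromo-4-fluorophenyl on an amide-type nitrogen. The two steps just named are the only ones touching this position, both small, and none swaps an aromatic ring for a small non-aromatic one. Compound 4 is therefore expected to show a 1.4-fold lower number from compound 3 to compound 4 (0.13 log units; within the scatter), nothing beyond the scatter. The estimate for compound 4 is 11 mL/min/kg, between 6 mL/min/kg and 20 mL/min/kg.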

Compound 4, clearance: 10 mL/min/kg
The estimate for compound 4 lay 1.1-fold (0.04 log units) above the measured number; the range from low to high includes it.
By their numbers in this assay, from the lowest: compounds 2, 4, 1 and 3 (each within the scatter of the next).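

Until now, this amide nitrogen had carried only substituted phenyl groups. Compound 4 shows that in this assay a non-aromatic cyclopropyl can stand there with every step inside the scatter: a 1.5-fold lower number from compound 3 to compound 4 (0.18 log units; within the scatter) and no change at the digits printed from compound 2 to compound 4 (within the scatter) and a 1.4-fold lower number from compound 1 to compound 4 (0.15 log units; within the scatter) are all that separate it from the aryl amides. This read-out therefore does not distinguish the three aryl groups from the much smaller ring, and nothing available explains that result. On these data alone, whether an amine, a carboxylic acid or a longer alkyl chain on this nitrogen would move clearance beyond the scatter remains open.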